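This account rests on a few compounds, and the source may have more. Where it says the series, first, only, none or still open, it means among the compounds named here.

Measured in a functional assay on MONO-MAC-6 cells (Homo sapiens) for cytotoxicity, read by MTT assay; a higher number here means a weaker inhibitor, a lower number a stronger inhibitor:
- compound 1 `O=C(N/N=C/c1cc(Cl)ccc1O)c1ccc(C(F)(F)F)cc1`: 5800 nM
- compound 2 `O=C(N/N=C/c1ccc(Cl)cc1)c1ccc(C(F)(F)F)cc1`: > 100000 nM

Compound 2 sits at the edge of what this assay can report, and its > 100000 nM is a limit and not a number. No true potency is therefore known for it.

The next compound, compound 3 `O=C(N/N=C/c1ccccc1O)c1ccc(C(F)(F)F)cc1`, has 2-hydroxyphenyl in place of 4-chlorophenyl on a carbon with a double bond to nitrogen.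

Compound 1 also carries a hydroxy group, and it gives a real reading of 5800 nM. On that single comparison, a large move towards stronger inhibition is expected, well beyond the scatter of repeated measurements. The expected change is an at least 8.3-fold lower number from compound 2 to compound 3 (0.92 log units; beyond the scatter), which can only be approximate when it starts from a limit.

For compound 3, the estimated value is 12000 nM, with an expected range of 3000 nM to 50000 nM.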

Compound 3, half-maximal inhibitory concentration: 2280 nM
Compound 3: the middle estimate sits 5.3-fold (0.72 log units) above what was measured; the measured number lies below the stated range.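

Putting 2-hydroxyphenyl in place of 4-chlorophenyl on a carbon with a double bond to nitrogen gives an at least 43-fold lower number from compound 2 to compound 3 (1.64 log units; beyond the scatter) in this assay, so this change at this position separates a compound with a real reading from one without. That step is only a minimum, since compound 2 gives a limit and not a number: the limit of > 100000 nM in this assay, at which 1 of the 3 values shown sits. Compound 1 and compound 3 both carry a hydroxy group, and hydrogen in place of chloro on an aromatic carbon gives a 2.5-fold lower number from compound 1 to compound 3 (0.41 log units; beyond the scatter) here, so the chloro group is not needed for a real reading.

On these data alone, what a methoxy group or an amine would give in place of the hydroxy group remains open. So does the effect of a nitrile in place of the trifluoromethyl group, which all three compounds share.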